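Stilbene series: methoxy addition next on the aminophenyl ring

The source may report more compounds than this note shows. Statements on the series, on what has been measured and on what is new or still open speak of the compounds shown alone.

Measured so far in a functional assay on HL-60 cells (Homo sapiens) for cytotoxicity; on this read-out lower numbers stand for stronger inhibition and higher numbers for weaker inhibition:
- compound 1 `CC1(C)CCC(C)(C)c2cc(/C=C/c3ccc(N)cc3)ccc21` gives 18000 nM
- compound 2 `CC1(C)CCC(C)(C)c2cc(/C=C/c3cccc(N)c3)ccc21` gives 20000 nM
- compound 3 `C/C(=C/c1ccccc1C(=O)O)c1ccc2c(c1)C(C)(C)CCC2(C)C` gives 52000 nM

Compound 2 holds the second highest of the three numbers in this assay. Among the compounds with values here, its nearest neighbour is compound 1; the only single-point step among the measured compounds runs a 1.1-fold higher number from compound 1 to compound 2 (0.05 log units; within the scatter), and that step stays within the scatter. Within the data shown here, compound 3 sits furthest away, with a higher number than compound 2 that lies beyond the scatter; no single-point step links compound 3 to the others, so its value stands on its own.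

Compound 4 `COc1ccc(/C=C/c2ccc3c(c2)C(C)(C)CCC3(C)C)cc1N` differs from compound 2 by methoxy in place of hydrogen on an aromatic carbon. Among the measured compounds shown here, no measured step adds or removes a methoxy group, so nothing bears directly on this change. For the measured compounds named here, the one step that is known, from compound 1 to compound 2, moved the amino group and stayed within the scatter. On that basis a step of no change at the digits printed from compound 2 to compound 4 (within the scatter) is expected, that is, no change beyond the scatter in either direction. Compound 4 is therefore estimated at 20000 nM, with a range from 8000 nM to 50000 nM.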

Compound 4, half-maximal inhibitory concentration: 61000 nM
Beside the measured number, compound 4's estimate is 3.1-fold (0.48 log units) below it; the measured number lies above the stated range.
By their numbers in this assay, from the lowest: compounds 1 and 2 (each within the scatter of the next); then compounds 3 and 4 (each within the scatter of the next).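

In this assay, methoxy in place of hydrogen on an aromatic carbon, ortho to an amino group and para to a large group, gives a 3.1-fold higher number from compound 2 to compound 4 (0.48 log units; beyond the scatter), so the number rises and inhibition weakens. Within the data shown here, this is the first single-point change to leave the scatter, whereas relocating the amino group gave only a 1.1-fold higher number from compound 1 to compound 2 (0.05 log units; within the scatter) and, read alone, suggested that the aminophenyl ring tolerates change; the added methoxy shows that this ring is not indifferent to every change. Among these compounds, nothing on hand accounts for the shift, and the size of this one step is the only information available on the added group.

The compounds shown leave open whether the rise belongs to methoxy itself or would follow any group on that aromatic carbon, such as a hydroxyl group, a fluorine atom or the longer ethoxy group. They also leave open whether methoxy would give a similar step on the ring of compound 1, where the amino group sits elsewhere, and whether a methoxy group on another aromatic carbon of the ring of compound 2 would do the same.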